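A few compounds are considered here, and "the series" means these few. Any claim that something is new, unique, unknown or untested is made for them only; others in the source may bear on it.

Three compounds share one core and differ only in the group on the six-membered carbon ring of the fused system. In an assay on isolated protein for inhibition of protein kinase C zeta type (Homo sapiens), read by 33P incorporation, tested at 200 uM (on this read-out lower numbers stand for a weaker effect and higher numbers for a stronger effect at the one concentration tested), compound 1 `O=C(O)CC(Cc1nc2cc(Cl)ccc2[nH]1)c1ccc(Cl)cc1` gives 70%, and compound 2 `O=C(O)CC(Cc1nc2cc(Br)ccc2[nH]1)c1ccc(Cl)cc1` gives 80%; the step of a number 10 percentage points higher from compound 1 to compound 2 (within the scatter) tells little on its own. Compound 3 `COc1ccc2[nH]c(CC(CC(=O)O)c3ccc(Cl)cc3)nc2c1` gives 0%, the lowest of the three numbers, reached through a number 70 percentage points lower from compound 1 to compound 3 (beyond the scatter) and a number 80 percentage points lower from compound 2 to compound 3 (beyond the scatter). Compound 4 `COC(=O)c1ccc2[nH]c(CC(CC(=O)O)c3ccc(Cl)cc3)nc2c1` carries a further change at the same place: methoxycarbonyl in place of methoxy on an aromatic carbon. Going by the values given here, no measured step covers an exchange of this kind. The two large steps that end at compound 3 show only that the chloro- and bromo-bearing compounds stand far above the methoxy-bearing one, and neither tells how a methoxycarbonyl group would compare. Compound 4 is therefore expected to come in at 20%, with a range from 0% to 55%, and the step of a number 20 percentage points higher from compound 3 to compound 4 (beyond the scatter) is to be read as an estimate rather than a measurement.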

Compound 4, a percentage reported as inhibition, at one concentration (the size of the read-out at that concentration, not a potency): 0%
Compound 4: middle estimate off by 20 percentage points, on the high side, and the stated range covers the measured number.
By their numbers in this assay, from the lowest: compounds 3 and 4 (each within the scatter of the next); then compounds 1 and 2 (each within the scatter of the next).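

In this assay the exchange of methoxy for methoxycarbonyl on this aromatic carbon brings no change at the digits printed from compound 3 to compound 4 (within the scatter) and so adds a second oxygen-bearing group to the low end of the series. Measured against the halogens, the exchange for bromo gives a number 80 percentage points lower from compound 2 to compound 4 (beyond the scatter) and the exchange for chloro gives a number 70 percentage points lower from compound 1 to compound 4 (beyond the scatter) in this set, so the large gap at this position is no longer tied to methoxy alone. Nothing available explains this split between the chloro and bromo compounds and the other two.

As far as these compounds go, whether an amine, a carboxylic acid, fluoro or methyl on this aromatic carbon would stand with chloro and bromo or with methoxy and methoxycarbonyl stays open. Also open, from the compounds shown here alone, is whether compound 3 and compound 4 would stay together at a concentration other than the single one tested.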